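The source may hold more compounds than are shown below. What is called first, only, known or untested is meant among the compounds shown, and "the series" means these compounds.

Compound 2 `C=C1[C@@H](OC(C)=O)C[C@@H]2[C@](C)(COC=O)[C@H](OC(C)=O)CC[C@@]2(C)[C@@H]1C[C@@H](Nc1cccc2ccccc12)C1=CCOC1=O` gives 32300 nM in a functional assay on KB cells (Homo sapiens) for cytotoxicity, read by sulforhodamine B assay (on this read-out lower numbers stand for stronger inhibition and higher numbers for weaker inhibition), the highest number of the three measured, with compound 1 `C=C1[C@@H](OC(C)=O)C[C@@H]2[C@](C)(CO[Si](C)(C)C(C)(C)C)[C@H](OC(C)=O)CC[C@@]2(C)[C@@H]1C[C@@H](Nc1ccc(C(=O)O)cc1)C1=CCOC1=O` at 5540 nM and compound 3 `C=C1[C@@H](OC(C)=O)C[C@@H]2[C@](C)(CO[Si](C)(C)C(C)(C)C)[C@H](OC(C)=O)CC[C@@]2(C)[C@@H]1C[C@@H](Nc1ccc(Br)cc1)C1=CCOC1=O` at 5230 nM. Compound 4 `C=C1[C@@H](OC(C)=O)C[C@@H]2[C@](C)(COC=O)[C@H](OC(C)=O)CC[C@@]2(C)[C@@H]1C[C@@H](Nc1ccc(F)cc1)C1=CCOC1=O` differs from compound 2 by 4-fluorophenyl in place of naphthalen-1-yl on an amine nitrogen. For the measured compounds named here, the only single-point step so far, a 1.1-fold lower number from compound 1 to compound 3 (0.03 log units; within the scatter), concerns a substituent swap on a phenyl ring, not the change from a two-ring to a one-ring aryl group, so it bears on this step only loosely. Going by the values given here, compounds 1 and 3 differ from compound 2 at two places, so no direct step exists. Compound 4 is expected to give a lower number than compound 2, with a 3.6-fold lower number from compound 2 to compound 4 (0.55 log units; beyond the scatter) as the estimated step; the estimate for compound 4 is 9000 nM, within 3000 nM to 27000 nM.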

Compound 4, half-maximal inhibitory concentration: 22900 nM
For compound 4 the middle estimate is 2.5-fold (0.41 log units) below the measured one, within the range that was stated.
By their numbers in this assay, from the lowest: compounds 3 and 1 (each within the scatter of the next); then compounds 4 and 2 (each within the scatter of the next).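

In this assay, swapping naphthalen-1-yl for 4-fluorophenyl on the amine nitrogen gives a 1.4-fold lower number from compound 2 to compound 4 (0.15 log units; within the scatter). For the compounds shown here, this is the first step at this position to go from a two-ring to a one-ring aryl group, and it shows that such a reduction in ring count need not move the number beyond the scatter. No measurement at hand accounts for this result.

Open, as far as these compounds go, is whether a non-aromatic group on this nitrogen, such as cyclohexyl or a straight alkyl chain, would keep or shift the number. Also open, from the compounds shown here alone, is how a methoxy group on the phenyl ring would read.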